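The compounds below may be only part of what the source reports. "The series", "measured", "known", "first", "only" and "open" are said of these compounds alone.

In a functional assay on SK-BR-3 cells (Homo sapiens) for inhibition, read by MTT assay (on this read-out lower numbers stand for stronger inhibition of growth and higher numbers for weaker inhibition of growth), compound 1 `CC1=C(/C=C/C(C)=C/C=C/C(C)=C\C(=O)Nc2cccc(F)c2)C(C)(C)CCC1n1ccnc1` gives 17000 nM. Two relatives have also been measured: compound 2 `CC1=C(/C=C/C(C)=C/C=C/C(C)=C\C(=O)NCc2ccc(O)cc2)C(C)(C)CC=C1c1cncnc1` gives 11500 nM, and compound 3 `CC1=C(/C=C/C(C)=C/C=C/C(C)=C\C(=O)Nc2ccccc2)C(C)(C)CC=C1c1cncnc1` gives 31000 nM. The value of compound 1 lies within the usual scatter of both, so it cannot be ranked against either.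

Compound 4 `CC1=C(/C=C/C(C)=C/C=C/C(C)=C\C(=O)NCc2ccc(F)cc2)C(C)(C)CCC1n1ccnc1` has 4-fluorobenzyl in place of 3-fluorophenyl on an amide-type nitrogen. The group on that nitrogen therefore changes while the rest of compound 1 stays the same.

For the measured compounds named here, one measured step bears on this change. With phenyl in place of 4-hydroxybenzyl on an amide-type nitrogen, the result is a 2.7-fold higher number from compound 2 to compound 3 (0.43 log units; beyond the scatter). Read in reverse, this modest step links a benzyl-type group on that nitrogen with a lower number than a phenyl group. The guide is thin, though: it is a single pair, its core differs from the core of compound 1, and its groups carry no fluorine. A modest move towards stronger inhibition of growth is still the reasonable expectation, of about the same size as that step. The expected change is a 2.1-fold lower number from compound 1 to compound 4 (0.33 log units; beyond the scatter). Compound 4 is expected at about 8000 nM, with an estimated range of 3500 nM to 17000 nM.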

Compound 4, concentration for 50% growth inhibition: 5500 nM
Compound 4: the middle estimate sits 1.5-fold (0.16 log units) above what was measured; low and high end bracket the measured number.
By their numbers in this assay, from the lowest: compound 4; then compounds 2, 1 and 3 (each within the scatter of the next, the first and the last beyond it).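

In this assay, replacing 3-fluorophenyl with 4-fluorobenzyl on the amide-type nitrogen gives a 3.1-fold lower number from compound 1 to compound 4 (0.49 log units; beyond the scatter), so the group on this nitrogen also matters on this core, not only on the different core of the earlier pair. The two pairs now point the same way, with the benzyl-type group giving the lower number in each, and this holds here with fluorine on both groups, whereas the earlier pair carried no fluorine. Nothing shown here explains why the number falls with this change.

This step also combines two differences, the change from phenyl to benzyl and the change in fluorine position from 3 to 4, and the compounds shown cannot separate them. On the same core, 4-fluorophenyl or 3-fluorobenzyl would help to tell these two differences apart, while a longer chain such as 2-phenylethyl would test whether the number keeps falling as the ring moves further from the amide-type nitrogen.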